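A few compounds are considered here, and "the series" means these few. Any claim that something is new, unique, unknown or untested is made for them only; others in the source may bear on it.

Compound 3 `C/C=C\c1nc(CC/C=C\C(=O)O[C@H]2C[C@@H]3CC(=O)O[C@@H](CCC)C[C@@H](OC)C/C(C)=C\[C@H](C2)O3)co1` gives 440 nM in a functional assay on PANC-1 cells (Homo sapiens) for antiproliferative activity, read by WST assay, with a stated time of 96 h (on this read-out lower numbers stand for stronger inhibition and higher numbers for weaker inhibition), the highest number of the three measured compounds; compound 2 `CCC[C@H]1C[C@@H](OC)C/C(C)=C\[C@@H]2C[C@@H](OC(=O)/C=C\CCc3coc(/C=C\CNC(=O)OC)n3)C[C@H](CC(=O)O1)O2` gives 2.4 nM and compound 1 `CCC[C@H]1C[C@@H](OC)C/C(C)=C\[C@@H]2C[C@@H](OC(=O)CCCCc3coc(/C=C\CNC(=O)OC)n3)C[C@H](CC(=O)O1)O2` gives 26 nM. For the measured compounds named here, the one step that bears on the next change is a 180-fold higher number from compound 2 to compound 3 (2.26 log units; beyond the scatter). Compound 4 `CCC[C@H]1C[C@@H](OC)C/C(C)=C\[C@@H]2C[C@@H](OC(=O)/C=C\CCc3coc(CCCNC(=O)OC)n3)C[C@H](CC(=O)O1)O2` differs from compound 3 by 3-((methoxycarbonyl)amino)propyl in place of prop-1-en-1-yl on an aromatic carbon. This reverses the loss of the (methoxycarbonyl)amino group, while the chain that carries it now lacks its double bond. He therefore expects a large step down in this assay for compound 4, of the order a 55-fold lower number from compound 3 to compound 4 (1.74 log units; beyond the scatter), because of a 180-fold higher number from compound 2 to compound 3 (2.26 log units; beyond the scatter), though compound 1 and compound 2 show that a saturated chain may blunt part of the gain. Compound 4 is estimated at 8 nM, between 2 nM and 40 nM.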

Compound 4, half-maximal inhibitory concentration: 200 nM
For compound 4 the middle estimate is 25-fold (1.40 log units) below the measured one, and the stated range ends below it.
By their numbers in this assay, from the lowest: compound 2; then compound 1; then compound 4; then compound 3.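

In this assay, the 3-((methoxycarbonyl)amino)propyl group gives only a 2.2-fold lower number from compound 3 to compound 4 (0.34 log units; beyond the scatter) and so recovers little of what separates compound 3 from compound 2. Its double bond is the sole difference in the chain on this aromatic carbon between compound 2 and compound 4, yet saturating it gives an 83-fold higher number from compound 2 to compound 4 (1.92 log units; beyond the scatter) and thus costs most of that gain. Nothing measured here explains this loss.

The compounds shown leave open whether a longer chain carrying the double bond would hold the low number of compound 2. They also leave open whether a free amine could replace the (methoxycarbonyl)amino group on that chain.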